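Chloro for fluoro on the benzoyl ring, second position

A few compounds are considered here, and "the series" means these few. Any claim that something is new, unique, unknown or untested is made for them only; others in the source may bear on it.

Measured so far in a functional assay on a cell-free system (Platelet, plasma, Homo sapiens) for inhibition; on this read-out higher numbers stand for weaker inhibition and lower numbers for stronger inhibition: compound 1 `Cc1ccc(N(CCN2CCC(OCC(=O)O)CC2)C(=O)c2ccc(F)cc2)cc1` gives 970 nM; compound 2 `Cc1ccc(N(CCN2CCC(OCC(=O)O)CC2)C(=O)c2ccc(Cl)cc2)cc1` gives 690 nM; compound 3 `O=C(O)COC1CCN(CCN(C(=O)c2cccc(F)c2)c2ccc(Cl)cc2)CC1` gives 340 nM.

Compound 4 `O=C(O)COC1CCN(CCN(C(=O)c2cccc(Cl)c2)c2ccc(Cl)cc2)CC1` is not yet measured in this assay. It differs from compound 3 by chloro in place of fluoro on an aromatic carbon. The same exchange is seen once before, in the pair that is measured: compound 2 differs from compound 1 by chloro in place of fluoro on an aromatic carbon, and that step made a 1.4-fold lower number from compound 1 to compound 2 (0.15 log units; within the scatter). The two places are not identical: in compound 1 the exchanged group sits para to a large group, in compound 3 meta to a large group, so the change is the same kind of change rather than the same one. The difference between the two cores, compound 1 against compound 3, is not broken down here. Compound 3 gives the lowest number of the three, and its gaps to compound 2 and compound 1 lie beyond the scatter.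

Compound 4 is expected to land near 260 nM, between 120 nM and 600 nM. The expected step of a 1.3-fold lower number from compound 3 to compound 4 (0.12 log units; within the scatter) rests on the earlier step of a 1.4-fold lower number from compound 1 to compound 2 (0.15 log units; within the scatter).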

Compound 4, half-maximal inhibitory concentration: 350 nM
Compound 4: middle estimate off by 1.3-fold (0.13 log units), on the low side, and the stated range covers the measured number.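

In this assay, chloro in place of fluoro on the aromatic carbon of the 3-fluorophenyl group gives a 1.0-fold higher number from compound 3 to compound 4 (0.01 log units; within the scatter), so compound 3 and compound 4 stand within the scatter of each other. Set beside the same exchange on the other core, the new step does not differ from the earlier one beyond the scatter: the same change on two cores in this assay, a 1.4-fold lower number (0.15 log units; within the scatter) from compound 1 to compound 2 and a 1.0-fold higher number (0.01 log units; within the scatter) from compound 3 to compound 4, 1.4-fold (0.16 log units) apart, within the scatter of two such steps

On these two cores, then, the exchange carries across without a step beyond the scatter on either; this does not show that it would behave the same way on other cores, and two pairs give no cause for the result and do not separate the effect of the place on the ring from that of the core.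

Open, as far as these compounds go, is whether bromo, trifluoromethyl or methoxy at the same place would give a step beyond the scatter. Also open, from the compounds shown here alone, is whether the exchange would read the same with a tetrazole or a methyl ester in place of the carboxylic acid.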